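Aromatic swaps and an iodo group on the shared core

This account rests on a few compounds, and the source may have more. Where it says the series, first, only, none or still open, it means among the compounds named here.

Values in an ADME assay on BJ cells (Homo sapiens), read by MTT assay, with a stated time of 72 h (a higher number here means a weaker inhibitor, a lower number a stronger inhibitor), follow
- compound 1 `CNc1ncnc2c1c(-c1ccoc1)cn2[C@@H]1O[C@H](CO)[C@@H](O)[C@H]1O` gives 96300 nM
- compound 2 `CNc1ncnc2c1c(-c1ccccc1)cn2[C@@H]1O[C@H](CO)[C@@H](O)[C@H]1O` gives > 100000 nM as a limit of the assay, not a number
- compound 3 `CNc1ncnc2c1c(-c1cc3ccccc3o1)cn2[C@@H]1O[C@H](CO)[C@@H](O)[C@H]1O` gives 75600 nM

Among the compounds with values here, compound 3 stands within the scatter of compound 1, the step being (a 1.3-fold lower number from compound 1 to compound 3 (0.11 log units; within the scatter)) and the only other reading a limit. Against compound 2 the step is (an at least 1.3-fold lower number from compound 2 to compound 3 (0.12 log units; that floor lies within the scatter)), and the step between the other two is (an at least 1.0-fold higher number from compound 1 to compound 2 (0.01 log units; that floor lies within the scatter)). In this assay the three aromatic groups are therefore not separated.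

Compound 4 `CNc1ncnc2c1c(I)cn2[C@@H]1O[C@H](CO)[C@@H](O)[C@H]1O` carries the next change (iodo in place of 1-benzofuran-2-yl on an aromatic carbon), with iodo in place of 1-benzofuran-2-yl on an aromatic carbon of a five-membered aromatic ring with 1 nitrogen. The three measured steps all exchange one aromatic group for another at this same carbon, so they bear on the change only indirectly, and none of them removes the aromatic group altogether. With no measured step beyond the scatter, no step beyond the scatter is expected in either direction, though the range is kept wide and a reading at the limit remains possible. The expected step is (a 1.1-fold higher number from compound 3 to compound 4 (0.02 log units; within the scatter)) in size. The estimate for compound 4 is (80000 nM), within an expected range from (30000 nM) to (100000 nM).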

Compound 4, half-maximal inhibitory concentration: > 100000 nM
Compound 4 ended at the assay's limit; the forecaster's own chance of this, stated with the estimate: 40%; middle value at least 1.2-fold (0.09 log units) from the limit.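

In this assay compound 4, the first compound shown with no ring on this aromatic carbon, gives > 100000 nM, which is a limit of the assay and not a number. Exchanging a two-ring aromatic group of 9 heavy atoms for a single iodine atom gives an at least 1.3-fold higher number from compound 3 to compound 4 (0.12 log units; that floor lies within the scatter), and exchanging furan-3-yl for iodo gives an at least 1.0-fold higher number from compound 1 to compound 4 (0.01 log units; that floor lies within the scatter); both floors lie within the scatter, so the iodo compound is not separated from the compounds bearing these aromatic groups, and a ring at this carbon is not shown to matter in this assay. The steps involving two limits cannot be read, and the series now presses against a single ceiling: the limit of > 100000 nM in this assay, at which 2 of the 4 values shown sit.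

From the compounds shown here alone, how far compound 4 lies past that limit remains open, so the true size of the change from an aromatic group to iodo is unknown. Also open, going by these compounds, is whether an amine, a carboxylic acid or a longer alkyl chain on this carbon would give a reading beyond the scatter of compound 1 and compound 3 in this assay.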